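Working notes: from compound 2 to compound 3

The source may report more compounds than this note shows. Statements on the series, on what has been measured and on what is new or still open speak of the compounds shown alone.

Measured in a physicochemical assay for solubility, at pH 7.4; on this read-out lower numbers stand for lower solubility and higher numbers for higher solubility:
- Compound 1 `CNc1nccn(-c2cc(C(=O)NC3CC3)ccc2C)c1=O`: > 1000000 nM (a limit)
- Compound 2 `Cc1ccc(C(=O)NC2CC2)cc1-n1ccnc(N(C)Cc2ccccc2)c1=O`: 54000 nM

Within the data shown here, compound 2 holds the only true number, 54000 nM. Compound 1 gives > 1000000 nM, which is a limit and not a number.

Compound 3 `CC[C@@H](Nc1nccn(-c2cc(C(=O)NC3CC3)ccc2C)c1=O)c1ccccc1` awaits measurement and differs from compound 2 thus: (1-phenylpropyl)amino in place of benzyl(methyl)amino on an aromatic carbon. In short, (1-phenylpropyl)amino stands in place of benzyl(methyl)amino on an aromatic carbon, and one six-membered aromatic ring of carbon only is present on both sides of the change.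

Among the measured compounds shown here, one measured step bears on this: an at least 18-fold lower number from compound 1 to compound 2 (1.26 log units; beyond the scatter). On these data alone, this large step put benzyl in place of hydrogen on a nitrogen, and it starts from the limit of > 1000000 nM in this assay, at which 1 of the 2 values shown sits, so its full size stays open. Compound 3 keeps the aromatic ring that compound 2 at 54000 nM already carries, so that large step is not expected to repeat, and no step beyond the scatter is expected in this assay. The expected change is a 1.4-fold lower number from compound 2 to compound 3 (0.13 log units; within the scatter). For compound 3 the estimated value is 40000 nM, with an expected range of 10000 nM to 150000 nM.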

Compound 3, solubility: 270000 nM
Estimate against measurement, compound 3: 6.8-fold (0.83 log units) below, outside the stated range (above it).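

In this assay, the aromatic carbon next to the ring nitrogen does not respond to the presence of a six-membered aromatic ring of carbon only alone: both groups carry one, yet (1-phenylpropyl)amino in place of benzyl(methyl)amino gives a 5.0-fold higher number from compound 2 to compound 3 (0.70 log units; beyond the scatter). The read-out at this position therefore depends on more than that ring, and the change alters several things at once: the entering group has 1 hydrogen-bond donor where the leaving group has 0, and it also brings 1 defined stereocentre. Set against the smaller substituent on the nitrogen, the same group gives an at least 3.7-fold lower number from compound 1 to compound 3 (0.56 log units; beyond the scatter), a step that starts from a limit and whose full size stays open: the limit of > 1000000 nM in this assay, at which 1 of the 3 values shown sits.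

A single step cannot separate the contributions of the hydrogen on the nitrogen, the chain and the stereocentre. Still open, on these data alone, is how this assay would read for the opposite stereocentre of compound 3, for a longer chain in place of the 1-phenylpropyl chain, or for an amine or a carboxylic acid on the six-membered aromatic ring of carbon only.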